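Removing a Methoxy Group: From One Core to Another

The source may report more compounds than this note shows. Statements on the series, on what has been measured and on what is new or still open speak of the compounds shown alone.

Measured so far:
compound 1 `O=C(/C=C/c1cc(Br)ccc1O)c1ccc(Br)cc1`, 28.7%
compound 2 `COc1cc(Br)cc(/C=C/C(=O)c2ccc(Br)cc2)c1O`, 64.6%
compound 3 `COC(=O)C1=C(N)Oc2c(OC)cc(Br)cc2C1CC(=O)c1ccc(Br)cc1`, 50.2%

All three were tested in a functional assay on MCF7 cells (Homo sapiens) for antiproliferative activity, read by sulforhodamine B assay, with a stated time of 72 h, tested at 10 uM; on this read-out higher numbers stand for a weaker effect at the one concentration tested and lower numbers for a stronger effect. Compound 2 and compound 1 share a core and differ in one place: hydrogen in place of methoxy on an aromatic carbon. That single change made a large step, a number 35.9 percentage points lower from compound 2 to compound 1 (beyond the scatter), so the compound without the methoxy group showed the stronger effect. Compound 3 is built on a different core, and the difference between the two cores is not broken down here; in this assay compound 3 gives 50.2%, between the other two.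

Compound 4 `COC(=O)C1=C(N)Oc2ccc(Br)cc2C1CC(=O)c1ccc(Br)cc1` has not yet been measured. It differs from compound 3 by hydrogen in place of methoxy on an aromatic carbon. Going by the values given here, this is the same kind of change as the one from compound 2 to compound 1, but not the same: there the methoxy group sat ortho to a hydroxy group and meta to a large group, whereas here it sits ortho to a fused ring and meta to a fused ring, within a fused or bridged system of two rings. Among the compounds with values here, only one earlier example of this change exists, and it comes from a different core, so the expectation rests on it loosely. Because the earlier step of a number 35.9 percentage points lower from compound 2 to compound 1 (beyond the scatter) was large, a step in the same direction is expected, though smaller, estimated as a number 18.2 percentage points lower from compound 3 to compound 4 (beyond the scatter). Compound 4 is therefore estimated at 32%, expected to lie between 10% and 58%.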

Compound 4, a percentage reported as activity, at one concentration (the size of the read-out at that concentration, not a potency): 72.5%
Compound 4: middle estimate off by 40.5 percentage points, on the low side; measured number above the stated range.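

Removing the methoxy group does not carry over from one core to the other as a simple rule. In this assay the change gives a number 22.3 percentage points higher from compound 3 to compound 4 (beyond the scatter), so on this core the compound without the methoxy group shows the weaker effect, the opposite of what the same swap did on the core of compound 1. The two steps run in opposite directions, and the gap between them is real rather than noise: the same change on two cores in this assay, a number 35.9 percentage points lower (beyond the scatter) from compound 2 to compound 1 and a number 22.3 percentage points higher (beyond the scatter) from compound 3 to compound 4, 58.2 percentage points apart, beyond the scatter of two such steps. This shows that, for these two cores, the outcome of the swap depends on the core that carries it, so the step seen on one core could not be transferred to the other. It does not show which feature of the cores is responsible, and with one pair on each core it gives no general rule for other cores.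

The compounds shown have only methoxy or hydrogen at this place, so it remains open how an ethoxy group, a hydroxy group or a fluoro group there would behave on either core. All four compounds also keep both bromo groups, which leaves open whether the opposite steps would persist with a chloro group in their place.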